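Ester in place of a hydroxyalkyl chain on a shared core

A few compounds are considered here, and "the series" means these few. Any claim that something is new, unique, unknown or untested is made for them only; others in the source may bear on it.

Compound 1 `NCCCCCCOc1ccc2c(=O)c(-c3ccc(O)cc3)coc2c1`: >> 9000 nM
Compound 2 `O=c1c(-c2ccc(O)cc2)coc2cc(OCCCCCCCCCO)ccc12`: > 9000 nM

In an assay (Cricetulus griseus) for inhibition of Monoamine oxidase (Homo sapiens) (on this read-out lower numbers stand for stronger inhibition and higher numbers for weaker inhibition), compound 1 gives >> 9000 nM, which is a limit of the assay. Compound 2 gives > 9000 nM, likewise a limit. The step that the two limits leave unreadable from compound 1 to compound 2 is therefore unreadable in size. Compound 3 `CCOC(=O)CCCCOc1ccc2c(=O)c(-c3ccc(O)cc3)coc2c1` differs from compound 2 by ethoxycarbonyl in place of 5-hydroxypentyl on a saturated chain carbon, four bonds along the chain from an oxygen on an aromatic ring. Among the compounds with values here, compound 2 itself stands only at a limit, and the single measured step offers no readable size to carry over. Compound 3 is thus expected to remain near that limit, at an estimated 20000 nM (range 6000 nM to 80000 nM). The expected step is a step that the limit leaves unreadable from compound 2 to compound 3.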

Compound 3, half-maximal inhibitory concentration: > 9000 nM
Compound 3 gave a limit, no number; the forecaster's own chance of this, stated with the estimate: 85%; the middle value lies beyond the limit too.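

In this assay, within the data shown here, compound 3 gives > 9000 nM, a limit, so no step from compound 1 or compound 2 to compound 3 can be read. The compounds shown leave open how strongly any of the three inhibits and whether these chain changes alter that.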